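The source may hold more compounds than are shown below. What is called first, only, known or untested is meant among the compounds shown, and "the series" means these compounds.

Measured in a functional assay on OCI-Ly10 cells (Homo sapiens) for cytotoxicity, read by CCK-8 assay, with a stated time of 72 h; on this read-out higher numbers stand for weaker inhibition and lower numbers for stronger inhibition:
- compound 1 `Cn1cc(NC(=O)c2ncn3ccc(N4CCC[C@@H](N)C4)nc23)c(C(F)F)n1`: > 50000 nM (a limit)
- compound 2 `Cn1cc(NC(=O)c2cnc3ccc(N[C@@H]4CCCNC4)nn23)c(C(F)F)n1`: 700 nM
- compound 3 `Cn1cc(NC(=O)c2cnc3ccc(N[C@H]4CCCNC4)nn23)c(C(F)F)n1`: 22300 nM

Compound 1 gives only a limit and not a number. Of the two true numbers in this assay, compound 3 holds the higher, with a 32-fold higher number from compound 2 to compound 3 (1.50 log units; beyond the scatter). That gap goes with configuration alone because of the fact that compounds 2 and 3 differ only in the configuration as drawn.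

Compound 4 `Cn1cc(NC(=O)c2cnc3ccc(N[C@@H]4CCCCNC4)nn23)c(C(F)F)n1` has azepan-3-yl in place of piperidin-3-yl on a nitrogen on an aromatic ring. Among the measured compounds shown here, no measured step changes this ring's size. For the measured compounds named here, the only step that bears on it is the large one at the same group, and compound 3 shows with a 32-fold higher number from compound 2 to compound 3 (1.50 log units; beyond the scatter) that the number responds strongly there. With compound 3 at the high end and compound 2 at 700 nM, a sizeable move toward lower numbers is expected, though with wide uncertainty. The expected change is a 7.4-fold lower number from compound 3 to compound 4 (0.87 log units; beyond the scatter). Compound 4 is expected at 3000 nM, with an estimated range of 500 nM to 20000 nM.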

Compound 4, half-maximal inhibitory concentration: 800 nM
For compound 4 the middle estimate is 3.8-fold (0.57 log units) above the measured one; measured number inside the range.
By their numbers in this assay, from the lowest: compounds 2 and 4 (each within the scatter of the next); then compound 3. At a limit, above all of these: compound 1.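

In this assay, the seven-membered azepan-3-yl ring on the nitrogen matches the six-membered piperidin-3-yl ring of the better of the two earlier compounds, with a 1.1-fold higher number from compound 2 to compound 4 (0.06 log units; within the scatter). Among the compounds shown here, the earlier step at this group changed only the configuration, so this is the first sign that the position accepts a larger ring without losing ground. Against the other piperidin-3-yl compound the same exchange reads as a 28-fold lower number from compound 3 to compound 4 (1.45 log units; beyond the scatter), a large step, but that compound carries the high number of the pair, so the comparison with compound 2 says more about ring size.

From the compounds shown here alone, it remains open whether the mirror-image azepan-3-yl would lose as much as the piperidin-3-yl pair does. Going by these compounds, how a smaller pyrrolidin-3-yl ring or a methyl group on the ring nitrogen would read also remains open.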